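A few compounds are considered here, and "the series" means these few. Any claim that something is new, unique, unknown or untested is made for them only; others in the source may bear on it.

Measured so far:
- compound 1 `CC(C)CCN(CCC(C)C)c1ccc(C(=O)N2CCc3ccc(OS(N)(=O)=O)cc3C2)cc1`: 90.8%
- compound 2 `CCN(Cc1ccc(F)cc1)c1cccc(C(=O)N2CCc3ccc(OS(N)(=O)=O)cc3C2)c1`: 66.5%
- compound 3 `NS(=O)(=O)Oc1ccc2c(c1)CN(C(=O)c1cccc(N3CCN(Cc4ccccc4)CC3)c1)CC2`: 23.7%

These three share a core carrying a sulfamate group and differ in the amine attached to the benzamide ring. In an assay on HEK293 cells for inhibition of Steryl-sulfatase (Homo sapiens), tested at 1 uM (a higher number here means a stronger effect of the compound at the concentration tested, a lower number a weaker effect), compound 1 gives the highest of the three numbers; compound 2 sits lower by a step beyond the scatter, and compound 3 lies far below both.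

Compound 4 `CCN(Cc1ccccc1)c1ccc(C(=O)N2CCc3ccc(OS(N)(=O)=O)cc3C2)cc1` is the untested compound. It differs from compound 1 in one place: benzyl(ethyl)amino in place of diisopentylamino on an aromatic carbon

Going by the values given here, no measured pair isolates this exact change, so the size of the step is uncertain. Compound 2, which carries a related benzyl-type amine, gives 66.5% in this assay, which suggests a drop. The step from compound 1 to compound 4 is expected to be a number 20.8 percentage points lower from compound 1 to compound 4 (beyond the scatter). Compound 4 is estimated at 70%, within a range of 45% to 90%.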

Compound 4, a percentage reported as inhibition, at one concentration (the size of the read-out at that concentration, not a potency): 83.6%
Compound 4: middle estimate off by 13.6 percentage points, on the low side; the range from low to high includes it.
By their numbers in this assay, from the lowest: compound 3; then compound 2; then compounds 4 and 1 (each within the scatter of the next).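

In this assay, putting benzyl(ethyl)amino in place of diisopentylamino on this aromatic carbon gives a number 7.2 percentage points lower from compound 1 to compound 4 (within the scatter). The earlier compounds shown here offered no pair differing in one place; this pair shows that an amine carrying a six-membered aromatic ring and one with no ring cannot be told apart in this read-out at this position. Nothing measured here offers an explanation for this result. Still open, going by these compounds, is how a much smaller group at this position, such as dimethylamino or a primary amine, would read in this assay.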